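Swapping Hydroxy for Methyl: Expected Half-Life of Compound 4

This account rests on a few compounds, and the source may have more. Where it says the series, first, only, none or still open, it means among the compounds named here.

Of the compounds shown here, three have been measured in an ADME assay on microsomes from liver (Mus musculus) for metabolic stability, read by LC-MS, using NADPH, tested at 10 uM; a lower number here means that the compound disappears faster, a higher number that the compound lasts longer. Compound 1 `O=C(NCc1ccc(F)cc1)c1ccc(N2CCN(S(=O)(=O)c3cccnc3O)CC2)nn1` stands highest of the three, giving 1.2 h in this assay. Its nearest neighbour on the numbers is compound 3 `O=C(NCc1ccccc1)c1ccc(N2CCC(S(=O)(=O)c3cccc(Cl)c3Cl)CC2)nn1`, which in this assay gives 0.333 h, a difference beyond the scatter. The furthest is compound 2 `O=C(NCc1ccccc1)c1ccc(N2CCN(S(=O)(=O)c3cccc(Cl)c3Cl)CC2)nn1`, which in this assay gives 0.233 h, also beyond the scatter. For the measured compounds named here, compounds 2 and 3 differ from compound 1 in more than one place, so no single step between measured compounds is available, and what they show is only that the shared core can carry values spanning this range.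

The next compound, compound 4 `Cc1ncccc1S(=O)(=O)N1CCN(c2ccc(C(=O)NCc3ccc(F)cc3)nn2)CC1`, follows from compound 1 by one change: methyl in place of hydroxy on an aromatic carbon.

Going by the values given here, no measured pair isolates this change. The account therefore rests on compound 1 alone as the anchor, with the lower values of compound 2 and compound 3 as a reminder of where the series can fall. The step from compound 1 to compound 4 is expected to be a moderate decrease, of about a 2.0-fold lower number from compound 1 to compound 4 (0.30 log units; within the scatter), close to the edge of the scatter rather than a large one. For compound 4 the half-life in this assay is estimated at 0.6 h, within a range of 0.25 h to 1.5 h.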

Compound 4, half-life: 0.133 h
Beside the measured number, compound 4's estimate is 4.5-fold (0.65 log units) above it; the measured number lies below the stated range.
By their numbers in this assay, from the lowest: compounds 4, 2 and 3 (each within the scatter of the next, the first and the last beyond it); then compound 1.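

In this assay, for the compounds shown here, the change from 2-hydroxypyridin-3-yl to 2-methylpyridin-3-yl gives a 9.0-fold lower number from compound 1 to compound 4 (0.96 log units; beyond the scatter), the first step that can be read at a single place. It shows that this position, on an aromatic carbon next to the ring nitrogen and ortho to a large group, is sensitive in this assay: within this pair, the longer half-life goes with hydroxy and is lost with methyl. Nothing given here bears on why the half-life moves in this way.

From the compounds shown here alone, this single pair cannot separate the effect of losing hydroxy from that of bringing in methyl, so it remains open which of the two drives the step. The compounds shown also leave open how other groups would behave at the same position, such as a methoxy group, an amine or a plain hydrogen, and whether the same change would give a step of similar size on another part of the shared core.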